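The source may hold more compounds than are shown below. What is called first, only, known or untested is meant among the compounds shown, and "the series" means these compounds.

Working notes on the series built on the core of compound 1 `Cc1cccc(Cn2cc(COc3ccc4c(=O)ccoc4c3)nn2)c1`. In a functional assay on HeLa cells (Homo sapiens) for cytotoxicity, read by MTT assay, with a stated time of 48 h (on this read-out higher numbers stand for weaker inhibition and lower numbers for stronger inhibition), compound 1 gives only a limit, > 100000 nM. Compound 2 `COc1ccc(Cn2cc(COc3ccc4c(=O)ccoc4c3)nn2)cc1` gives 14400 nM in this assay. Compound 3 `O=c1ccoc2cc(OCc3cn(Cc4ccc(Br)cc4)nn3)ccc12` likewise stops at a limit, > 100000 nM. Of the measured steps, an at least 6.9-fold lower number from compound 1 to compound 2 (0.84 log units; beyond the scatter), whereas a step that the two limits leave unreadable from compound 1 to compound 3, and an at least 6.9-fold higher number from compound 2 to compound 3 (0.84 log units; beyond the scatter). Compound 4 `N#Cc1cccc(Cn2cc(COc3ccc4c(=O)ccoc4c3)nn2)c1` differs from compound 1 by cyano in place of methyl on an aromatic carbon, that is 3-methylbenzyl to 3-cyanobenzyl. Within the data shown here, no measured step swaps cyano for methyl, and compound 1 stands at the limit of > 100000 nM in this assay, at which 2 of the 3 values shown sit, so the change cannot be read off any step; the one number below the limit belongs to compound 2 alone. Compound 4 is therefore expected to stay near the limit, an at least 1.2-fold lower number from compound 1 to compound 4 (0.09 log units; that floor lies within the scatter), with an estimate of 80000 nM spanning 20000 nM to 300000 nM.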

Compound 4, half-maximal inhibitory concentration: > 100000 nM
Compound 4 was reported as a limit; the forecaster's own chance of this, stated with the estimate: 60%; at least 1.2-fold (0.09 log units) between middle value and limit.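

In this assay compound 4 gives > 100000 nM, which is a limit. Cyano in place of methyl on this aromatic carbon yields no number below the limit, the steps from compound 1 and compound 3 cannot be read, and the limit now holds most of the series: the limit of > 100000 nM in this assay, at which 3 of the 4 values shown sit. The one readable step is an at least 6.9-fold higher number from compound 2 to compound 4 (0.84 log units; beyond the scatter), leaving 4-methoxyphenyl the only group here with a measured number.

Open, from the compounds shown here alone, is whether methoxy would give a number on the aromatic carbon that carries cyano in compound 4. Also open, going by these compounds, is whether an amine or a carboxylic acid there would give one.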